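Ortho-halogen swap in a small imidazole-fused series

This account rests on a few compounds, and the source may have more. Where it says the series, first, only, none or still open, it means among the compounds named here.

Measured compounds:
compound 1 `Fc1ccccc1C1Cc2nccn2C1`, 63%
compound 2 `COc1ccc(C2Cc3nccn3C2)cc1`, 27%

The two measured compounds share one core and differ only in the substituted phenyl group. In a functional assay on CHO cells for agonist activity at Alpha-1A adrenergic receptor (Homo sapiens), read by FLIPR and calcium flux (on this read-out higher numbers stand for larger maximal responses and lower numbers for smaller maximal responses), compound 1 gives 63%, the higher of the two numbers; compound 2 gives 27%, lower by a margin beyond the scatter. Going by the values given here, no single-point step between measured compounds exists, so the effect of one substituent change on the maximal response is not yet defined within this set.

Compound 3 `Clc1ccccc1C1Cc2nccn2C1` keeps the core and the substitution pattern of compound 1. The change is chloro in place of fluoro on an aromatic carbon of a six-membered aromatic ring of carbon only. Both groups count one heavy atom, carry no donors or acceptors and no charge.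

Among the compounds with values here, with no measured step of this kind available, the expectation for this assay is a small step, if any, within the scatter, in either direction. For compound 3 the estimated value is 65%, range 42% to 85%, which means an expected step of a number 2 percentage points higher from compound 1 to compound 3 (within the scatter).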

Compound 3, largest response reached (Emax), in percent of the reference or control that the assay uses: 56%
For compound 3 the middle estimate is 9 percentage points above the measured one; the measured number falls inside the stated range.
By their numbers in this assay, from the lowest: compound 2; then compounds 3 and 1 (each within the scatter of the next).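

Chloro in place of fluoro on an aromatic carbon, ortho to a group of 8 heavy atoms, gives the first single-place step in this series. In this assay that step reads a number 7 percentage points lower from compound 1 to compound 3 (within the scatter), so at this position the maximal response does not separate the two halogens. Going by these compounds alone, the earlier pair could not show this, since it offered no step at a single place; this position now accepts either of these one-atom groups with no change that can be told from the scatter, though that holds only for this one exchange. Nothing measured here bears on the reason for this result.

Still open, as far as these compounds go, is whether the same position keeps its maximal response with a group that is more than a single halogen atom, such as an amine, a carboxylic acid or a longer alkyl chain, which would test how far the tolerance seen with fluoro and chloro extends. Also open, from the compounds shown here alone, is whether bromo on this carbon fits the same picture, and whether chloro on another carbon of the aromatic ring gives a step of similar size.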